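Swapping the benzyl aryl group on a trimethoxyaniline amide

This account rests on a few compounds, and the source may have more. Where it says the series, first, only, none or still open, it means among the compounds named here.

Compound 1 `COc1cc(NCc2cccc(O)c2)cc(OC)c1OC`: 57600 nM
Compound 2 `C/C=C/C(=O)N(Cc1ccc(OC)c(C)c1)c1cc(OC)c(OC)c(OC)c1`: 14500 nM

In a functional assay on MGC-803 cells (Homo sapiens) for inhibition, read by MTT assay, with a stated time of 48 h (on this read-out lower numbers stand for stronger inhibition and higher numbers for weaker inhibition), compound 2 gives the lower of the two values, 14500 nM, and so shows the stronger inhibition. Compound 3 `C/C=C/C(=O)N(Cc1cccc(O)c1)c1cc(OC)c(OC)c(OC)c1` departs from it in one place: 3-hydroxyphenyl in place of 4-methoxy-3-methylphenyl on a saturated chain carbon bound to an amide-type nitrogen. Within the data shown here, no measured pair isolates this change. Compound 1 also carries the 3-hydroxyphenyl but differs elsewhere too, and it gives 57600 nM. A small rise in this assay is therefore expected, perhaps none beyond the scatter. The expected change is a 1.5-fold higher number from compound 2 to compound 3 (0.18 log units; within the scatter). For compound 3 the estimated value is 22000 nM, within a range of 7000 nM to 60000 nM.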

Compound 3, half-maximal inhibitory concentration: 14100 nM
Compound 3: middle estimate off by 1.6-fold (0.19 log units), on the high side; low and high end bracket the measured number.
By their numbers in this assay, from the lowest: compounds 3 and 2 (each within the scatter of the next); then compound 1.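

In this assay, 3-hydroxyphenyl and 4-methoxy-3-methylphenyl cannot be told apart at this saturated chain carbon (a 1.0-fold lower number from compound 2 to compound 3 (0.01 log units; within the scatter)). With 3-hydroxyphenyl held fixed, (prop-1-en-1-yl)carbonyl in place of hydrogen on the nitrogen brings a real gain (a 4.1-fold lower number from compound 1 to compound 3 (0.61 log units; beyond the scatter)). No evidence on hand bears on the reason for either step.

Going by these compounds, whether an unsubstituted phenyl, or a phenyl carrying an amine or a carboxylic acid, would also hold the value of compound 3 remains open. So does the effect of a longer acyl chain on that nitrogen.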